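This account rests on a few compounds, and the source may have more. Where it says the series, first, only, none or still open, it means among the compounds named here.

Compound 1 `Nc1scc(CN2CCN(c3ccc(OC(F)(F)F)cc3)CC2)c1C(=O)c1ccc(Cl)cc1` is measured in an assay on CHO cells for displacement of a labelled ligand from adenosine receptor A1 (Homo sapiens), read by scintillation counting, with a stated time of 120 min, tested at 10 uM; a lower number here means less inhibition, a higher number more inhibition at the concentration tested (going by the name of the read-out): compound 1 gives 0%. Compound 2 `Nc1scc(CN2CCC(c3ccc(Cl)cc3)CC2)c1C(=O)c1ccc(Cl)cc1` gives 0% and compound 3 `Nc1scc(CN2CCN(c3cccc(F)c3)CC2)c1C(=O)c1cccc(C(F)(F)F)c1` gives 0%, so all three measured compounds sit level in this assay, within the scatter of one another. The next compound, compound 4 `Nc1scc(CN2CCN(c3c(F)cc(F)cc3F)CC2)c1C(=O)c1ccc(Cl)cc1`, differs from compound 1 in one place: 2,4,6-trifluorophenyl in place of 4-(trifluoromethoxy)phenyl on an amine nitrogen in a ring. Nothing measured in the series separates any pair of compounds beyond the scatter, so the step in this assay is expected to be none beyond the scatter, and the expected step is a number 2 percentage points higher from compound 1 to compound 4 (within the scatter). Compound 4 is therefore expected to give 2% in this assay, within the range -8% to 15%.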

Compound 4, a percentage reported as inhibition, at one concentration (the size of the read-out at that concentration, not a potency): 0%
Beside the measured number, compound 4's estimate is 2 percentage points above it; the measured number falls inside the stated range.
By their numbers in this assay, from the lowest: compounds 1, 2, 3 and 4 (each within the scatter of the next).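

In this assay the series now has its first single-place step, no change at the digits printed from compound 1 to compound 4 (within the scatter), with 2,4,6-trifluorophenyl in place of 4-(trifluoromethoxy)phenyl on the amine nitrogen in the ring. This exchange of one substituted phenyl for another therefore leaves the read-out within the scatter, so the pair gives no sign of what this position contributes. No measurement at hand offers an explanation for the result. As far as these compounds go, whether a carboxylic acid, a primary amine or a longer alkyl chain at this nitrogen would give any measurable inhibition remains open.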